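This account rests on a few compounds, and the source may have more. Where it says the series, first, only, none or still open, it means among the compounds named here.

Measured so far:
Compound 1, `C=COc1cc(N2CCCNCC2)cnc1Br`, in an assay on HEK293 cells for displacement of a labelled ligand from Neuronal acetylcholine receptor; alpha4/beta2 (Homo sapiens) (a lower number here means a stronger inhibitor, a higher number a weaker inhibitor), gives 0.646 nM.
Compound 2, `Oc1cncc(N2CCCNCC2)c1`, in this assay gives 2.4 nM.

Of the two numbers, compound 2 has the higher one, so it is the weaker binder of the pair; the gap to compound 1 is beyond the usual scatter of this kind of measurement. Among the compounds with values here, no step between two measured compounds that differ in only one place is available, so any expectation for a new compound must rest on the two values alone.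

Compound 3, `C=COc1cncc(N2CCCNCC2)c1`, differs from compound 2 in one place: vinyl in place of hydrogen on an oxygen on an aromatic ring. Compound 1 carries the same vinyloxy group together with a further substituent and gives a lower number than compound 2, which hints that the change may help, but this cannot be separated from the other difference.

The step is expected to be small and towards a lower number, roughly a 1.6-fold lower number from compound 2 to compound 3 (0.20 log units; within the scatter). Compound 3 is therefore expected to give about 1.5 nM, with a likely range from 0.5 nM to 4.5 nM.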

Compound 3, half-maximal inhibitory concentration: 5.01 nM
For compound 3 the middle estimate is 3.3-fold (0.52 log units) below the measured one, and the stated range ends below it.
By their numbers in this assay, from the lowest: compound 1; then compound 2; then compound 3.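

On the oxygen on the aromatic ring, vinyl in place of hydrogen weakens binding in this assay (a 2.1-fold higher number from compound 2 to compound 3 (0.32 log units; beyond the scatter)), so the vinyloxy group alone does not account for the low number of compound 1. Within the vinyloxy pair, hydrogen in place of bromo on an aromatic carbon costs more (a 7.8-fold higher number from compound 1 to compound 3 (0.89 log units; beyond the scatter)), which ties the strong binding of compound 1 to its bromo group rather than to its vinyloxy group. Nothing available explains why either change has this effect.

Going by these compounds, it remains open whether a saturated group on the oxygen, such as methyl or a longer alkyl chain, would also weaken binding as vinyl does. Also open, on these data alone, is whether bromo would bring a similar gain alongside the hydroxy group of compound 2, and whether chloro could replace it.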